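Ester-linked benzyl series: aldehyde to hydrate step

The compounds below may be only part of what the source reports. "The series", "measured", "known", "first", "only" and "open" are said of these compounds alone.

Compound 1 `CCOC(=O)CCCCCOc1ccc(CNC(C)C)cc1`: in an ADME assay on HEK293 cells (Homo sapiens) for cytotoxicity, read by CellTiter-Glo and resazurin assay, with a stated time of 72 h (a higher number here means that more compound is needed for the effect, a lower number that less compound is needed), compound 1 reaches only the assay limit > 26000 nM.
Compound 2 `CCCNCc1ccc(OCCCCCC(=O)OCC)cc1`: in this assay compound 2 likewise stops at the limit > 26000 nM.
Compound 3 `CCOC(=O)CCCCCOc1ccc(C=O)cc1`: in this assay compound 3 also gives only the limit > 26000 nM.

Compound 3 therefore stands at the same limit as compound 1 and compound 2 (the limit of > 26000 nM in this assay, at which 3 of the 3 values shown sit). The change to compound 4 `CCOC(=O)CCCCCOc1ccc(C(O)O)cc1` is dihydroxymethyl in place of formyl on an aromatic carbon. Within the data shown here, the steps that bear on it are a step that the two limits leave unreadable from compound 1 to compound 2, a step that the two limits leave unreadable from compound 1 to compound 3 and a step that the two limits leave unreadable from compound 2 to compound 3, and none of them can be sized because every value sits at the limit (the limit of > 26000 nM in this assay, at which 3 of the 3 values shown sit). No step beyond the scatter is expected, so compound 4 is estimated to give a step that the limit leaves unreadable from compound 3 to compound 4. Compound 4 is expected at 40000 nM, within 20000 nM to 100000 nM, most likely again only a limit.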

Compound 4, half-maximal effective concentration: > 27100 nM
Compound 4 was reported as a limit; the forecaster's own chance of this, stated with the estimate: 85%; the middle value lies beyond the limit too.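

Compound 4 also gives only a limit, so the steps to it from compound 1, compound 2 and compound 3 cannot be read. The compounds shown leave open whether any change on the shared core gives a readable value in this assay.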